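Phenyl removal from compound 1: expected growth inhibition

The compounds below may be only part of what the source reports. "The series", "measured", "known", "first", "only" and "open" are said of these compounds alone.

In a functional assay on K562 cells (Homo sapiens) for antiproliferative activity, read by MTT assay, with a stated time of 48 h (a higher number here means a weaker inhibitor of growth, a lower number a stronger inhibitor of growth), compound 1 (`CCOc1cc(NC(=O)CCCCC(=O)Nc2cc(-c3ccccc3)ccc2N)cc2c1OCC([N+](=O)[O-])=C2`) gives 5270 nM as the higher of the two numbers available, and compound 2 (`CCOc1cc(NC(=O)CCCCCCC(=O)Nc2cc(-c3ccccc3)ccc2N)cc2c1OCC([N+](=O)[O-])=C2`) gives 2000 nM as the lower, a gap beyond the usual scatter. Compound 3 (`CCOc1cc(NC(=O)CCCCC(=O)Nc2ccccc2N)cc2c1OCC([N+](=O)[O-])=C2`) departs from compound 1 (hydrogen in place of phenyl on an aromatic carbon) with hydrogen in place of phenyl on an aromatic carbon, para to an amino group. Going by the values given here, no measured pair shows this change, so the data offer no direct guide to its size. In this assay no step beyond the scatter is expected in either direction, and the range is kept wide on both sides. The estimate means a 1.3-fold lower number from compound 1 to compound 3 (0.12 log units; within the scatter) as the expected step. Compound 3 is estimated at 4000 nM with 1500 nM to 11000 nM as the expected range.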

Compound 3, concentration for 50% growth inhibition: 3680 nM
For compound 3 the middle estimate is 1.1-fold (0.04 log units) above the measured one, and the stated range covers the measured number.
By their numbers in this assay, from the lowest: compounds 2, 3 and 1 (each within the scatter of the next, the first and the last beyond it).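

Working from the core of compound 1, hydrogen in place of phenyl on the aromatic carbon para to an amino group gives a 1.4-fold lower number from compound 1 to compound 3 (0.16 log units; within the scatter) in this assay. On this chain, the phenyl can therefore be removed from this position, with its six carbon atoms and its aromatic ring, without a step beyond the scatter; at this level of growth inhibition, the ring is not required. No available evidence bears on why this change produces so small a step.

From the compounds shown here alone, whether the same replacement stays within the scatter on the longer chain of compound 2 remains open. Also open, going by these compounds, is whether a smaller group at this carbon, such as fluorine or methoxy, or another ring, such as pyridyl or thienyl, would shift the number beyond the scatter.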